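Substituent at the chain carbon on the core: compound 3

A few compounds are considered here, and "the series" means these few. Any claim that something is new, unique, unknown or untested is made for them only; others in the source may bear on it.

Measured so far:
- compound 1, `CN(C)Cc1nc2ccccc2c(-c2ccccc2)c1C(=O)NCc1cc(C(F)(F)F)cc(C(F)(F)F)c1`: 0.22 nM
- compound 2, `CN1CCN(Cc2nc3ccccc3c(-c3ccccc3)c2C(=O)NCc2cc(C(F)(F)F)cc(C(F)(F)F)c2)CC1`: > 1000 nM

In an in vitro assay on UC11MG cells for binding affinity to Substance-P receptor (Homo sapiens), read by radioligand binding (on this read-out higher numbers stand for weaker inhibition and lower numbers for stronger inhibition), compound 1 gives 0.22 nM. Compound 2 returns only a limit, > 1000 nM, so compound 2 stands on no number of its own but at the limit of > 1000 nM in this assay, at which 1 of the 2 values shown sits. Going by the values given here, the single step between them, an at least 4500-fold higher number from compound 1 to compound 2 (3.65 log units; beyond the scatter), shows that what sits on the saturated chain carbon bound to an aromatic carbon can move this assay by a large amount.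

Compound 3, `CC(C)(C)[Si](C)(C)OCc1nc2ccccc2c(-c2ccccc2)c1C(=O)NCc1cc(C(F)(F)F)cc(C(F)(F)F)c1`, carries a group of 8 heavy atoms (6 carbon, 1 oxygen, 1 silicon; no ring) in place of a group of 7 heavy atoms (5 carbon, 2 nitrogen; one six-membered non-aromatic ring with 2 hetero atoms), on a saturated chain carbon bound to an aromatic carbon. Among the compounds with values here, only the step from compound 1 to compound 2 bears on this change, and it was large; since compound 2 is known only as a limit, the size of the step toward compound 3 cannot be pinned down from it. A downward step is expected, an at least 20-fold lower number from compound 2 to compound 3 (1.30 log units; beyond the scatter), with wide uncertainty. Compound 3 is estimated at 50 nM, between 2 nM and 1000 nM.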

Compound 3, half-maximal inhibitory concentration: 17 nM
Beside the measured number, compound 3's estimate is 2.9-fold (0.47 log units) above it, within the range that was stated.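

In this assay, the saturated chain carbon bound to an aromatic carbon can carry a group with no nitrogen and no ring and still give a far lower number than 4-methylpiperazin-1-yl, with an at least 58-fold lower number from compound 2 to compound 3 (1.76 log units; beyond the scatter). Compound 2 is known only as a limit, so that step is a bound and not a measured size: the limit of > 1000 nM in this assay, at which 1 of the 3 values shown sits.

Dimethylamino in compound 1 still gives the lowest number of the three compounds, with a 77-fold higher number from compound 1 to compound 3 (1.89 log units; beyond the scatter), so the group with oxygen and silicon retains measurable binding without matching dimethylamino.

Going by these compounds alone, with only three groups at this place, the effects of ring, nitrogen and group size cannot be separated from one another. From the compounds shown here alone, how a hydroxyl group, a methoxy group or a pyrrolidin-1-yl group would read at the same place remains open.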